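Selenium-Bearing Chain in Place of an Amine on a Quinazoline Core

The compounds below may be only part of what the source reports. "The series", "measured", "known", "first", "only" and "open" are said of these compounds alone.

Measured compounds:
compound 1, `COc1ccc(N(C)c2nc(C)nc3ccccc23)cc1OCCN`, 343 nM
compound 2, `C[Se]c1ccc(N(C)c2nc(C)nc3ccccc23)cc1C`, 6 nM

Within the data shown here, in a functional assay on HepG2 cells (Homo sapiens) for inhibition, read by MTT assay, with a stated time of 48 h (a higher number here means a weaker inhibitor, a lower number a stronger inhibitor), compound 1 gives 343 nM, the higher of the two numbers known here. Compound 2 gives 6 nM, a gap that lies well beyond the usual scatter, so compound 2 is the stronger inhibitor of the pair; the two differ in more than one place, so only the values themselves can be compared.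

Compound 3, `COc1ccc(N(C)c2nc(C)nc3ccccc23)cc1OCCCCC[Se]C#N`, has not been measured. It differs from compound 1 as follows: a group of 6 heavy atoms (4 carbon, 1 nitrogen, 1 selenium; no ring) in place of one nitrogen atom, on a saturated chain carbon, two bonds along the chain from an oxygen on an aromatic ring. Among the measured compounds shown here, no single-change step is available to anchor this move, so the expectation rests on the two values alone. Compound 3 is expected to come in somewhat stronger than compound 1, with the step of a 3.4-fold lower number from compound 1 to compound 3 (0.54 log units; beyond the scatter) estimated to reach beyond the scatter. In this assay compound 3 is thus estimated at 100 nM, within a range of 20 nM to 500 nM.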

Compound 3, half-maximal inhibitory concentration: 5210 nM
Compound 3: middle estimate off by 52-fold (1.72 log units), on the low side, outside the stated range (above it).
By their numbers in this assay, from the lowest: compound 2; then compound 1; then compound 3.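

At this place, on a saturated chain carbon, two bonds along the chain from an oxygen on an aromatic ring, the amino group and the selenium-bearing group are far from interchangeable: in this assay the swap gives a 15-fold higher number from compound 1 to compound 3 (1.18 log units; beyond the scatter) and lies beyond the scatter. Among these compounds, this is the first single-place change available on the shared core, and it shows that the value depends strongly on what the end of this chain carries. It also shows that putting selenium into this chain does not, in this one case, give a lower number. Nothing measured here bears on the reason for the step.

Chain length and the selenium-bearing end change together in this one step, so their shares stay open. A longer chain ending in an amine, or a carbon chain ending in a nitrile without selenium, would separate them.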